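A Swap on the Triazole Nitrogen, Read on Liver Cells

A few compounds are considered here, and "the series" means these few. Any claim that something is new, unique, unknown or untested is made for them only; others in the source may bear on it.

Compound 1 `CCOc1ccc(-n2nncc2CN2C(=O)C3(C(C#N)=C(N)Oc4c3c3nc5ccccc5nc3c3ccccc43)c3ccccc32)cc1` and compound 2 `N#CC1=C(N)Oc2c(N)cc3nc4ccccc4nc3c2C12C(=O)N(Cc1cnnn1-c1ccccc1Cl)c1ccccc12` share one core and carry different groups on an aromatic nitrogen. In an ADME assay on L02 cells (Homo sapiens) for antiproliferative activity, read by MTT assay, with a stated time of 48 h (a higher number here means a weaker inhibitor, a lower number a stronger inhibitor), compound 1 reaches only the limit of the assay, giving > 50000 nM. Compound 2 likewise reaches only the limit in this assay, with > 50000 nM. Compound 2 is not alone in this: the limit of > 50000 nM in this assay, at which 2 of the 2 values shown sit. Among the measured compounds shown here, no step between two measured compounds is available here, so the size of a change at this place has not yet been seen in numbers.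

Compound 3 `Cc1cc(C)cc(-n2nncc2CN2C(=O)C3(C(C#N)=C(N)Oc4c(N)cc5nc6ccccc6nc5c43)c3ccccc32)c1` has not been measured. It differs from compound 2 in one place: 3,5-dimethylphenyl in place of 2-chlorophenyl on an aromatic nitrogen. With both known values sitting at the limit, no direction can be read off, and the most natural expectation is that compound 3 also ends at the limit or, if a number appears, lands within the scatter of compound 2. Compound 3 is expected to give about 50000 nM in this assay, inside a range from 20000 nM to 120000 nM. That expectation means a step of a number no higher from compound 2 to compound 3 (the limit leaves the size open), which is no step beyond the scatter.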

Compound 3, half-maximal inhibitory concentration: > 50000 nM
Compound 3: a limit, no number (the forecaster's own chance of this, stated with the estimate: 80%); the middle value sits exactly at the limit.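

In this assay compound 3 gives > 50000 nM, which is a limit and not a number. Compound 2 also sits at a limit, so no step between compound 2 and compound 3 can be read: the limit of > 50000 nM in this assay, at which 3 of the 3 values shown sit.

The compounds shown leave open whether any group on this aromatic nitrogen would give a measurable number in this assay.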